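Swapping a ring fluoro for a methyl near the amide

This account rests on a few compounds, and the source may have more. Where it says the series, first, only, none or still open, it means among the compounds named here.

Measured compounds:
Compound 1, `Cn1cc(-c2ccc(NC(=O)c3cn(CC4CCOCC4)cc(-c4ccc(F)cc4F)c3=O)cc2)c2c(N)ncnc21`, gives 0.8 nM.
Compound 2, `Cn1cc(-c2ccc(NC(=O)c3cn(CC4CCOCC4)cc(-c4ccc(F)cc4)c3=O)c(F)c2)c2c(N)ncnc21`, gives 0.2 nM.
Compound 3, `Cn1cc(-c2ccc(NC(=O)c3cn(CC4CCCCC4)cc(-c4ccc(F)cc4)c3=O)cc2)c2c(N)ncnc21`, gives 2.3 nM.

All three were tested in an assay on isolated protein for inhibition of tyrosine-protein kinase receptor UFO (Homo sapiens), read by ELISA; on this read-out higher numbers stand for weaker inhibition and lower numbers for stronger inhibition. Compound 2 has the lowest number of the three, and its distances to compound 1 and to compound 3 both lie beyond the usual scatter, so it is the strongest inhibitor among the measured set. Compound 4, `Cc1cc(-c2cn(C)c3ncnc(N)c23)ccc1NC(=O)c1cn(CC2CCOCC2)cc(-c2ccc(F)cc2)c1=O`, has not yet been measured. It differs from compound 2 in one place: methyl in place of fluoro on an aromatic carbon. Within the data shown here, since no two measured compounds differ in exactly this way, there is no measured step to lean on. A methyl and a fluoro are each a single heavy atom, neither adds a donor or acceptor, and the change sits on the same ring carbon. The expectation is a modest step in this assay, in the direction of a somewhat weaker inhibitor, of a size near the edge of the scatter; the estimated step of a 2.5-fold higher number from compound 2 to compound 4 (0.40 log units; beyond the scatter) reflects this. Compound 4 is therefore expected to give about 0.5 nM, most likely between 0.15 nM and 1.6 nM.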

Compound 4, half-maximal inhibitory concentration: 4 nM
For compound 4 the middle estimate is 8.0-fold (0.90 log units) below the measured one; the whole stated range lies below it.
By their numbers in this assay, from the lowest: compound 2; then compound 1; then compounds 3 and 4 (each within the scatter of the next).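

In this assay, methyl in place of fluoro on this aromatic carbon, ortho to a large group and meta to a large group, gives a 20-fold higher number from compound 2 to compound 4 (1.30 log units; beyond the scatter) and makes clear that inhibition depends strongly on what sits at this one position. Fluoro and methyl each count as a single heavy atom with no hydrogen-bond donors or acceptors, so those counts alone do not predict the outcome here. Nothing at hand explains why this exchange has so large an effect.

This single step cannot show whether fluoro is especially favourable here or methyl especially unfavourable, a question that a chloro or a methoxy on the same carbon of compound 2 could help to address. It also leaves open whether the same exchange would have a similar effect with different groups elsewhere on the molecule.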